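This account rests on a few compounds, and the source may have more. Where it says the series, first, only, none or still open, it means among the compounds named here.

Measured compounds:

Compound 1 `CCc1cnc(N2CCC(c3nc(COc4ccc(-n5cnnn5)cc4)cs3)CC2)nc1`, in an ADME assay on microsomes from liver (Homo sapiens) for metabolic stability, with a stated time of 30 min; a higher number here means that more of the compound is left, a lower number that less of the compound is left: 7.8%

Compound 2 `CCc1cnc(N2CCC(c3nc(COc4ccc(/C=C5\CC(=O)NC5=O)cc4F)cs3)CC2)nc1`, in this assay: 48.9%

Compound 2 holds the higher of the two numbers in this assay. Its nearest neighbour is compound 1, which in this assay gives 7.8%, a result that lies far lower, well beyond the usual scatter. Compound 2 itself gives 48.9%. The two compounds differ in more than one place, so no single step can be read from them, and only their two values speak.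

The account now follows the step from compound 2 to compound 3 `CCc1cnc(N2CCC(c3nc(COc4ccc(/C=C5\CC(=O)NC5=O)cc4C)cs3)CC2)nc1`. The change is small: methyl in place of fluoro on an aromatic carbon. For the measured compounds named here, no comparable step between measured compounds is available to lean on, so the expectation rests on the size of the change alone. A modest downward step is expected, a number 10.9 percentage points lower from compound 2 to compound 3 (beyond the scatter), though a result within the scatter of compound 2 would not be surprising. Compound 3 is therefore estimated to give 38% in this assay, with a likely range from 20% to 58%.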

Compound 3, percent of the compound remaining: 17.1%
The estimate for compound 3 lay 20.9 percentage points above the measured number, outside the stated range (below it).
By their numbers in this assay, from the lowest: compounds 1 and 3 (each within the scatter of the next); then compound 2.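

In this assay, for the compounds shown here, the exchange of fluoro for methyl is the first change that can be read on its own, and it gives a number 31.8 percentage points lower from compound 2 to compound 3 (beyond the scatter) in the percentage of compound remaining. The position on the aromatic carbon, ortho to a large group and meta to a group of 8 heavy atoms, is therefore not indifferent to what it carries, even though the leaving and entering groups each count a single heavy atom and neither carries a hydrogen-bond donor, a hydrogen-bond acceptor or a net charge. No measurement at hand explains why these two groups give such different results at this place.

The compounds shown leave open whether a chloro, methoxy or nitrile group at this position would give a result nearer to that of compound 2 or to that of compound 3. They also leave open whether the same exchange would give a step of similar size on the core of compound 1, since one pair cannot show whether the effect carries over to other compounds.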